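Working notes: thiophen-2-yl in place of 4-methoxyphenyl

The source may hold more compounds than are shown below. What is called first, only, known or untested is meant among the compounds shown, and "the series" means these compounds.

Measured in a functional assay on MOLT-4 cells (Homo sapiens) for antiproliferative activity; a lower number here means a stronger inhibitor, a higher number a weaker inhibitor:
- compound 1 `COc1cc(C(=O)c2sc(-c3ccccc3)cc2N)cc(OC)c1OC`: 5.3 nM
- compound 2 `COc1ccc(-c2cc(N)c(C(=O)c3cc(OC)c(OC)c(OC)c3)s2)cc1`: 18 nM

Of these two, compound 2 has the higher number, 18 nM. The next compound, compound 3 `COc1cc(C(=O)c2sc(-c3cccs3)cc2N)cc(OC)c1OC`, has not yet been measured. It differs from compound 2 by thiophen-2-yl in place of 4-methoxyphenyl on an aromatic carbon. Going by the values given here, the one measured step that bears on this is a 3.4-fold higher number from compound 1 to compound 2 (0.53 log units; beyond the scatter), with methoxy in place of hydrogen on an aromatic carbon. Among the compounds with values here, compound 3, like compound 1, has no methoxy on this group, but no thiophen-2-yl compound has been measured. A modest move to a lower number in this assay is therefore expected, no larger than that measured step. The estimated change is a 2.0-fold lower number from compound 2 to compound 3 (0.30 log units; within the scatter). For compound 3 the expected value is 9 nM, with an estimated range of 3 nM to 30 nM.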

Compound 3, half-maximal inhibitory concentration: 8.9 nM
For compound 3 the middle estimate is 1.0-fold (0.00 log units) above the measured one; the measured number falls inside the stated range.
By their numbers in this assay, from the lowest: compounds 1 and 3 (each within the scatter of the next); then compound 2.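

In this assay the place next to the ring sulfur accepts a five-membered aromatic ring as well as a six-membered one: thiophen-2-yl in place of phenyl gives a 1.7-fold higher number from compound 1 to compound 3 (0.23 log units; within the scatter) and so leaves the two groups within the scatter of each other. Thiophen-2-yl in place of 4-methoxyphenyl gives a 2.0-fold lower number from compound 2 to compound 3 (0.31 log units; beyond the scatter) and so, across compound 1 and compound 3, both groups without a methoxy give lower numbers than 4-methoxyphenyl does. No measurement at hand explains either step.

The compounds shown leave open whether this place also accepts a ring that is not aromatic, such as cyclohexyl, or a small chain such as ethyl. Also open, from the compounds shown here alone, is whether a fluoro or a hydroxyl on the phenyl group would shift the number as methoxy does.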